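Adding a Second Aminopropyl Arm to a Long Chain Polyamine

The compounds below may be only part of what the source reports. "The series", "measured", "known", "first", "only" and "open" are said of these compounds alone.

Among the compounds with values here, only two compounds have numbers so far. In a toxicity assay on CHO cells (Cricetulus griseus) for cytotoxicity, read by WST assay, with a stated time of 24 h (a lower number here means a stronger inhibitor, a higher number a weaker inhibitor), compound 1 (`CC(C)=CCCC(C)=CCNCCCN(CCCN)CCCN`) gives 127000 nM and compound 2 (`CC(C)=CCC/C(C)=C\CCC(C)=CCNCCCN(C)CCCN`) gives 10500 nM (the lower number of the pair). That gap lies well beyond the scatter of repeat measurements, so compound 2 stands as the stronger inhibitor of the two. These two compounds differ in more than one place, so their gap cannot be pinned on any single group.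

Compound 3 (`CC(C)=CCC/C(C)=C\CCC(C)=CCNCCCN(CCCN)CCCN`) alters compound 2 at one spot. On a saturated chain carbon bound to an amine nitrogen, 2-aminoethyl comes in place of hydrogen (2-aminoethyl in place of hydrogen on a saturated chain carbon bound to an amine nitrogen). Read one bond further out, (3-aminopropyl)(methyl)amino becomes bis(3-aminopropyl)amino, the same end that compound 1 carries. Within the data shown here, no measured pair shows this change alone. The only hint is the high number of compound 1 (127000 nM), so a small rise, about the size of the scatter, is expected. The expected change is a 1.5-fold higher number from compound 2 to compound 3 (0.18 log units; within the scatter) in this assay and remains an estimate. For compound 3 the estimated value is 16000 nM (range 6500 nM to 45000 nM).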

Compound 3, half-maximal inhibitory concentration: > 150000 nM
Compound 3 gave a limit, no number; the forecaster's own chance of this, stated with the estimate: 4%; at least 9.3-fold (0.97 log units) between middle value and limit.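

In this assay, replacing hydrogen with 2-aminoethyl on a saturated chain carbon bound to an amine nitrogen, which turns (3-aminopropyl)(methyl)amino into bis(3-aminopropyl)amino, now has a measured effect: the result is an at least 14-fold higher number from compound 2 to compound 3 (1.15 log units; beyond the scatter), so at this position the change gives a much weaker inhibitor. The second new step, 3-methylbut-2-en-1-yl in place of hydrogen on a saturated chain carbon bound to a double-bonded chain carbon, reads as an at least 1.1-fold higher number from compound 1 to compound 3 (0.07 log units; that floor lies within the scatter), and this floor alone does not establish any effect of that addition. The reading for compound 3 is a limit of the assay, not a number: the limit of > 150000 nM in this assay, at which 1 of the 3 values shown sits.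

From the compounds shown here alone, the true size of both steps stays open, since each rests on that limit and could be larger than its printed floor. Going by these compounds, it also remains open how this position would respond to a different end group on the added arm, such as a hydroxyl in place of the terminal amine or a carboxylic acid.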